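This account rests on a few compounds, and the source may have more. Where it says the series, first, only, none or still open, it means among the compounds named here.

Measured compounds:
Compound 1 `Cc1ccc(NC(=O)c2ccc(/N=N\c3c[nH]c4ccccc34)cc2)cc1` — in a functional assay on HCT-116 cells (Homo sapiens) for inhibition, read by MTT assay, with a stated time of 72 h (a higher number here means a weaker inhibitor, a lower number a stronger inhibitor), compound 1 gives 25400 nM.
Compound 2 `O=C(Nc1cccc(Cl)c1)c1ccc(/N=N\c2c[nH]c3ccccc23)cc1` — in this assay compound 2 gives 80000 nM.

Of the two numbers in hand, compound 1 has the lowest. Among the compounds with values here, its nearest neighbour is compound 2, and the only step between measured compounds runs from one to the other: a 3.1-fold higher number from compound 1 to compound 2 (0.50 log units; beyond the scatter). That step therefore sets the only reference for what a change on the amide-type nitrogen does in this assay.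

Compound 3 `O=C(Nc1cccc([N+](=O)[O-])c1)c1ccc(/N=N\c2c[nH]c3ccccc23)cc1` has not been measured. It differs from compound 1 in one place: 3-nitrophenyl in place of 4-methylphenyl on an amide-type nitrogen. Like the step to compound 2, this removes 4-methylphenyl from the amide-type nitrogen and puts a phenyl carrying a single group in the 3-position in its place. Within the data shown here, the one bearing step, a 3.1-fold higher number from compound 1 to compound 2 (0.50 log units; beyond the scatter), went towards a higher number and lay beyond the scatter, though it was modest. On that basis a higher number is expected for compound 3 as well, of roughly the same size, with wide uncertainty given that a single step is all there is to go on.

Compound 3 is estimated to give 60000 nM, in a range from 20000 nM to 180000 nM. The expected step is a 2.4-fold higher number from compound 1 to compound 3 (0.37 log units; beyond the scatter).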

Compound 3, half-maximal inhibitory concentration: 70100 nM
The estimate for compound 3 lay 1.2-fold (0.07 log units) below the measured number; measured number inside the range.
By their numbers in this assay, from the lowest: compound 1; then compounds 3 and 2 (each within the scatter of the next).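

In this assay, a second phenyl carrying a single group in the 3-position on the amide-type nitrogen again moves away from 4-methylphenyl in the same direction, with a 2.8-fold higher number from compound 1 to compound 3 (0.44 log units; beyond the scatter), so the earlier step no longer stands alone. The exchange of nitro for chloro on that aromatic carbon gives a 1.1-fold lower number from compound 2 to compound 3 (0.06 log units; within the scatter), which means that compound 2 and compound 3 cannot be told apart here, although the two groups share neither their atoms nor their size, and both numbers stay apart from that of compound 1. Nothing in hand gives a reason why these two groups read alike or why both differ from 4-methylphenyl.

The compounds shown leave open whether the higher numbers go with the 3-position or with the groups themselves, since 4-methylphenyl differs from both newer groups in its substituent and in where that substituent sits, a question that 3-methylphenyl or 4-chlorophenyl on the same nitrogen would address. They also leave open how an amine or a carboxylic acid in the 3-position would read in this assay, and whether any group here would give a lower number than compound 1 does.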